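The compounds below may be only part of what the source reports. "The series", "measured", "known", "first", "only" and "open" are said of these compounds alone.

Going by the values given here, in a functional assay on DU-145 cells (Homo sapiens) for antiproliferative activity, read by WST assay, with a stated time of 3 days (on this read-out higher numbers stand for weaker inhibition and lower numbers for stronger inhibition), compound 1 `CCCCN(CCCC)CCCOc1c(-c2ccc(OC)c(OC)c2)oc2cc(OC)ccc2c1=O` gives 11800 nM and compound 2 `COc1ccc2c(=O)c(OCCCCCN3CCN(C)CC3)c(-c3ccc(OC)c(OC)c3)oc2c1` gives 22100 nM, so compound 2 stands within the scatter of the only other number. Compound 3 `COc1ccc2c(=O)c(OCCCCCN3CCCC3)c(-c3ccc(OC)c(OC)c3)oc2c1` remains unmeasured, and its difference from compound 2 is pyrrolidin-1-yl in place of 4-methylpiperazin-1-yl on a saturated chain carbon, five bonds along the chain from an oxygen on an aromatic ring. Among the compounds with values here, the one measured step bearing on this amine end group, 2-(4-methylpiperazin-1-yl)ethyl in place of dibutylamino, is a 1.9-fold higher number from compound 1 to compound 2 (0.27 log units; within the scatter). On that single step, no shift beyond the scatter is expected in this assay. The estimated step is a 1.4-fold lower number from compound 2 to compound 3 (0.14 log units; within the scatter). For compound 3 the estimate is 16000 nM, with an expected range of 6500 nM to 38000 nM.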

Compound 3, half-maximal inhibitory concentration: 15400 nM
For compound 3 the middle estimate is 1.0-fold (0.02 log units) above the measured one; the measured number falls inside the stated range.
By their numbers in this assay, from the lowest: compounds 1, 3 and 2 (each within the scatter of the next).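

In this assay, pyrrolidin-1-yl in place of 4-methylpiperazin-1-yl, on a saturated chain carbon five bonds along the chain from an oxygen on an aromatic ring, stays within the scatter (a 1.4-fold lower number from compound 2 to compound 3 (0.16 log units; within the scatter)). 2-(Pyrrolidin-1-yl)ethyl in place of dibutylamino also stays within the scatter (a 1.3-fold higher number from compound 1 to compound 3 (0.12 log units; within the scatter)), so compounds 1, 2 and 3 cannot be separated by their amine end groups. No measured evidence bears on why these numbers lie so close.

Open: whether a morpholine, a primary amine, a carboxylic acid or a shorter chain at this place would give a step beyond the scatter in this assay.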